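This account rests on a few compounds, and the source may have more. Where it says the series, first, only, none or still open, it means among the compounds named here.

Compound 1 `O=C(CCCc1ccccc1)Nc1nc2ccccc2c(=O)s1` carries an unsubstituted phenyl group on its chain; in an assay on CHO cells for displacement of a labelled ligand from adenosine receptor A1 (Homo sapiens), read by scintillation counting, with a stated time of 90 min (on this read-out higher numbers stand for weaker inhibition and lower numbers for stronger inhibition), compound 1 gives 2500 nM. Compound 2 `O=C(CCCc1ccc(Cl)c(Cl)c1)Nc1nc2ccccc2c(=O)s1` bears a 3,4-dichlorophenyl group in the same place, but in this assay compound 2 gives "not determined" (no result reported), so it stands nowhere on the scale shown. Compound 3 `COc1cccc(CCCC(=O)Nc2nc3ccccc3c(=O)s2)c1` differs from compound 2 by 3-methoxyphenyl in place of 3,4-dichlorophenyl on a saturated chain carbon, three bonds along the chain from a carbonyl carbon. Within the data shown here, with no measured step to rest on, only compound 1 offers a reference point. Compound 3 is therefore expected to land near that value, with an estimate of 2500 nM and a range from 600 nM to 10000 nM.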

Compound 3, inhibition constant: 214 nM
Beside the measured number, compound 3's estimate is 12-fold (1.07 log units) above it; measured number outside the range, below it.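

In this assay, methoxy in place of hydrogen on an aromatic carbon gives a 12-fold lower number from compound 1 to compound 3 (1.07 log units; beyond the scatter), so the phenyl group on this chain is a place where a single added group changes the number beyond the scatter. Compound 2 has no reported result, so the 3,4-dichlorophenyl group offers no comparison with the 3-methoxyphenyl group. Nothing measured here accounts for this change. The compounds shown leave open whether a hydroxyl group or an amine on the phenyl group would give a similar number, and what a longer chain would do.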